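The source may hold more compounds than are shown below. What is called first, only, known or untested is meant among the compounds shown, and "the series" means these compounds.

Going by the values given here, in a functional assay on T47D cells (Homo sapiens) for inhibition, read by CCK-8 assay, with a stated time of 72 h, tested at 1 uM (a higher number here means more inhibition of growth at the concentration tested, a lower number less inhibition of growth), compound 2 `CN(C)C(=O)c1cc2cnc(Nc3ccc(NC(=O)C4(C(=O)Nc5cccc(O)c5)CC4)cc3)nc2n1C1CCCC1` gives 80.7%, the highest number among the three compounds measured so far. Compound 1 `CN(C)C(=O)c1cc2cnc(Nc3ccc(NC(=O)C4(C(=O)Nc5cccc(F)c5)CC4)cc3)nc2n1C1CCCC1` gives -3.2%, and the smaller compound 3 `Nc1ccc(NC(=O)C2(C(=O)Nc3ccc(F)cc3)CC2)cc1F` gives 5.6%. Compound 4 `CN(C)C(=O)c1cc2cnc(Nc3ccc(NC(=O)C4(C(=O)Nc5ccc(Cl)c(C(F)(F)F)c5)CC4)cc3)nc2n1C1CCCC1` keeps the core of compound 2 and changes one group on an amide-type nitrogen: 4-chloro-3-(trifluoromethyl)phenyl in place of 3-hydroxyphenyl on an amide-type nitrogen.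

Among the compounds with values here, only one measured step bears on this change. With hydroxy in place of fluoro on an aromatic carbon of that same group, the result is a number 83.9 percentage points higher from compound 1 to compound 2 (beyond the scatter), a large step beyond the scatter. Compound 4 also gives up the hydroxy group, so that step, read in reverse, points to a large fall. However, no measured compound carries the 4-chloro-3-(trifluoromethyl)phenyl group, so the size of the fall remains uncertain. The expected result is a number 55.7 percentage points lower from compound 2 to compound 4 (beyond the scatter). Compound 4 is estimated to give 25%, with an expected range of -5% to 75%.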

Compound 4, percent growth inhibition at one concentration: 6.9%
Compound 4: middle estimate off by 18.1 percentage points, on the high side, and the stated range covers the measured number.
By their numbers in this assay, from the lowest: compounds 1, 3 and 4 (each within the scatter of the next, the first and the last beyond it); then compound 2.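

In this assay, the change to 4-chloro-3-(trifluoromethyl)phenyl gives a number 73.8 percentage points lower from compound 2 to compound 4 (beyond the scatter), so the high number of compound 2 now stands against two groups without the hydroxy, not only against 3-fluorophenyl. Exchanging one of those groups for the other gives a number 10.1 percentage points higher from compound 1 to compound 4 (beyond the scatter), a much smaller step, and across compounds 1, 2 and 4 only the 3-hydroxyphenyl compound reaches a high number, with none of the three going against this. Nothing available explains why this group stands apart.

Still open, as far as these compounds go, is whether the high number needs the hydroxy group itself or would survive with a 3-aminophenyl or 3-methoxyphenyl group on the same amide-type nitrogen. Also open, from the compounds shown here alone, is whether a 4-hydroxyphenyl group there would give a similar number.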